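Methyl Sulfonate in Place of Tolyl Sulfonate on a Cytidine

This account rests on a few compounds, and the source may have more. Where it says the series, first, only, none or still open, it means among the compounds named here.

Compound 1 `Cc1ccc(S(=O)(=O)O[C@@H]2[C@@H](O)[C@H](n3ccc(N)nc3=O)O[C@@H]2CO)cc1`: > 30 ug/mL
Compound 2 `Nc1nc(=O)n(C2OC(CO)C(Cl)C2O)cc1F`: > 30 ug/mL
Compound 3 `Nc1nc(=O)n(C2OC(CO)C(Br)C2O)cc1F`: 5 ug/mL

In a functional assay on P815 cells (Mus musculus) for antiproliferative activity (a lower number here means a stronger inhibitor, a higher number a weaker inhibitor), compound 1 gives > 30 ug/mL, which is a limit of the assay and not a number. Compound 2 likewise gives only a limit, > 30 ug/mL. Compound 3 gives 5 ug/mL. Among the compounds with values here, the one step between measured compounds, an at least 6.0-fold lower number from compound 2 to compound 3 (0.77 log units; beyond the scatter), concerns bromo in place of chloro on a saturated ring carbon and leaves the sulfonyl group untouched. Compound 4 `CS(=O)(=O)O[C@@H]1[C@@H](O)[C@H](n2ccc(N)nc2=O)O[C@@H]1CO` differs from compound 1 by methyl in place of 4-methylphenyl on a sulfonyl sulfur. Within the data shown here, no measured step bears on this change, so the data give no direction for it, and compound 1 sits at the limit of > 30 ug/mL in this assay, at which 2 of the 3 values shown sit. Compound 4 is expected to remain near that limit, with a step that the limit leaves unreadable from compound 1 to compound 4 expected to be small. The estimate for compound 4 is 40 ug/mL, between 10 ug/mL and 150 ug/mL.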

Compound 4, concentration for 50% inhibition: 22 ug/mL
Estimate against measurement, compound 4: 1.8-fold (0.26 log units) above; the range from low to high includes it.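

In this assay compound 4 gives 22 ug/mL, the first number that can be read for a sulfonate among these compounds. Compound 1 gives > 30 ug/mL, which is a limit of the assay and not a number. Methyl in place of 4-methylphenyl on a sulfonyl sulfur thus gives an at least 1.3-fold lower number from compound 1 to compound 4 (0.13 log units; that floor lies within the scatter), and the true size of this step stays unknown: the limit of > 30 ug/mL in this assay, at which 2 of the 4 values shown sit.

The compounds shown leave open how an ethyl chain, a longer chain or an amine on the sulfonyl sulfur would compare with methyl.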